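Chloro in Place of Fluoro: From Compound 3 to Compound 4

A few compounds are considered here, and "the series" means these few. Any claim that something is new, unique, unknown or untested is made for them only; others in the source may bear on it.

Compound 1 `Cc1ccc(-n2cc(-c3ccc(NS(=O)(=O)c4c[nH]c(=O)[nH]c4=O)cc3)nn2)cc1`: in a functional assay on HepG2 cells (Homo sapiens) for antiproliferative activity, read by MTT assay, with a stated time of 24 h (a higher number here means a weaker inhibitor, a lower number a stronger inhibitor), compound 1 gives 11600 nM.
Compound 2 `O=c1[nH]cc(S(=O)(=O)Nc2ccc(-c3cn(-c4ccccc4F)nn3)cc2)c(=O)[nH]1`: in this assay compound 2 reaches only the limit of > 20000 nM.
Compound 3 `O=c1[nH]cc(S(=O)(=O)Nc2ccc(-c3cn(-c4ccc(F)cc4)nn3)cc2)c(=O)[nH]1`: in this assay compound 3 reaches only the limit of > 20000 nM.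

Compound 3 therefore stands at the ceiling of what this assay reports, not at a number; it shares that position with compound 2, as the limit of > 20000 nM in this assay, at which 2 of the 3 values shown sit, shows. On these data alone, only compound 1 gives a readable value, and the step of an at least 1.7-fold higher number from compound 1 to compound 3 (0.23 log units; that floor lies within the scatter) carries a floor that lies within the scatter, so how far compound 3 actually sits from compound 1 is unknown. Likewise an at least 1.7-fold higher number from compound 1 to compound 2 (0.23 log units; that floor lies within the scatter) gives only a floor, and a step that the two limits leave unreadable from compound 2 to compound 3 cannot be read at all, since both ends are limits.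

Compound 4 `O=c1[nH]cc(S(=O)(=O)Nc2ccc(-c3cn(-c4ccc(Cl)cc4)nn3)cc2)c(=O)[nH]1` differs from compound 3 by chloro in place of fluoro on an aromatic carbon. Within the data shown here, none of the measured steps exchanges one halogen for another, so no step bears directly on this change; the nearest is the methyl-to-fluoro step from compound 1 to compound 3, which ended at the limit. With compound 3 already at the limit, the expected step of a number no higher from compound 3 to compound 4 (the limit leaves the size open) cannot be told apart from none beyond the scatter, and compound 4 is most likely to return only a limit as well. Compound 4 is thus estimated at 20000 nM in this assay, within a range from 7000 nM to 40000 nM.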

Compound 4, half-maximal inhibitory concentration: 1980 nM
Compound 4: the middle estimate sits 10-fold (1.00 log units) above what was measured, outside the stated range (below it).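

In this assay the para position of this aryl group, para to a large group, turns out to distinguish one halogen from another: 4-chlorophenyl in place of 4-fluorophenyl gives an at least 10-fold lower number from compound 3 to compound 4 (1.00 log units; beyond the scatter). The change also separates compound 4 from the methyl compound, with a 5.9-fold lower number from compound 1 to compound 4 (0.77 log units; beyond the scatter), and from the compound carrying 2-fluorophenyl, with an at least 10-fold lower number from compound 2 to compound 4 (1.00 log units; beyond the scatter), which makes compound 4 the strongest of the four shown and shows that the earlier methyl-to-fluoro result did not mark the aryl substituent as a dead end. Two of these steps remain floors, not full sizes, because compound 2 and compound 3 each give only a limit, not a number: the limit of > 20000 nM in this assay, at which 2 of the 4 values shown sit.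

The compounds shown leave open how bromo, methoxy or trifluoromethyl would fare at this same position, and whether chloro would keep its effect as 2-chlorophenyl. They also do not tell why chloro differs from both fluoro and methyl here, and a single exchange of halogens cannot show whether any trend runs through the series.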